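The source may report more compounds than this note shows. Statements on the series, on what has been measured and on what is new or still open speak of the compounds shown alone.

- Compound 1 `COc1cccc(-c2nc3ccc(C)cc3c(=O)[nH]2)c1`: > 50000 nM
- Compound 2 `Cc1ccc2c(=O)[nH]c(-c3cccc(F)c3)nc2c1`: > 50000 nM

Both compounds were tested in a functional assay on T47D cells (Homo sapiens) for cytotoxicity, read by MTT assay, with a stated time of 2 days; a higher number here means a weaker inhibitor, a lower number a stronger inhibitor. In this test, compound 1 gives > 50000 nM, which is a limit of the assay and not a true number. Compound 2 gives > 50000 nM, and this too is a limit. Going by the values given here, the whole picture is therefore (the limit of > 50000 nM in this assay, at which 2 of the 2 values shown sit), so compound 1 has no exact value to start from, and no step between measured compounds is available as a guide.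

Compound 3 `Cc1ccc2nc(-c3cccc(OC(F)(F)F)c3)[nH]c(=O)c2c1` keeps the core of compound 1 and turns methoxy into trifluoromethoxy, with trifluoromethyl in place of methyl on an oxygen on an aromatic ring.

In this assay, no step beyond the usual scatter is expected, and a limit is the likeliest result. The estimated step of a number no higher from compound 1 to compound 3 (the limit leaves the size open) is expected to show no clear direction. For compound 3 the expected value is 50000 nM, with an estimated range from 20000 nM to 100000 nM.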

Compound 3, half-maximal inhibitory concentration: > 50000 nM
Compound 3 was reported as a limit (the forecaster's own chance of this, stated with the estimate: 75%); the middle value sits exactly at the limit.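

No step can be read from compound 1 to compound 3, because both results are limits and not true numbers: the limit of > 50000 nM in this assay, at which 3 of the 3 values shown sit.

The compounds shown leave open how strong any of them is in this assay, and whether swapping methoxy for trifluoromethoxy changes that strength at all.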